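Trimming the Amide to Acetyl: Cytotoxicity Expectation

The source may hold more compounds than are shown below. What is called first, only, known or untested is meant among the compounds shown, and "the series" means these compounds.

Compound 3 `COc1ccc(-c2cnc(NC(=O)c3cnc[nH]3)n2C)cc1` is the starting point. In a toxicity assay on THP-1 cells (Homo sapiens) for inhibition (on this read-out lower numbers stand for higher toxicity in this test and higher numbers for lower toxicity in this test), compound 3 gives > 100000 nM, which is a limit of the assay and not a number. Compound 1 `COc1ccc(-c2cnc(NC(=O)c3cccc(C#N)c3)n2C)cc1` gives > 100000 nM in this assay, also a limit. Compound 2 `COc1ccc(-c2cnc(NC(=O)c3cnco3)n2C)cc1` gives > 100000 nM, again a limit. Because of the limit of > 100000 nM in this assay, at which 3 of the 3 values shown sit, the steps a step that the two limits leave unreadable from compound 1 to compound 2, a step that the two limits leave unreadable from compound 1 to compound 3 and a step that the two limits leave unreadable from compound 2 to compound 3 have no readable size. Compound 4 `COc1ccc(-c2cnc(NC(C)=O)n2C)cc1` has not been measured; its change from compound 3 is methyl in place of 1H-imidazol-5-yl on a carbonyl carbon. Going by the values given here, no measured step bears on this change, and no step in this assay could be sized. Compound 4 is therefore expected to sit at the same limit, an estimated step that the limit leaves unreadable from compound 3 to compound 4, with an estimate of 150000 nM between 50000 nM and 500000 nM.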

Compound 4, half-maximal cytotoxic concentration: > 100000 nM
Compound 4 ended at the assay's limit (the forecaster's own chance of this, stated with the estimate: 85%); the middle value lies beyond the limit too.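

No step among compound 1, compound 2, compound 3 and compound 4 can be read, because all of them stop at one limit: the limit of > 100000 nM in this assay, at which 4 of the 4 values shown sit.

As far as these compounds go, whether the groups on the carbonyl carbon differ at all in this assay remains open.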